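Dropping the Fluorine from Compound 3

The source may report more compounds than this note shows. Statements on the series, on what has been measured and on what is new or still open speak of the compounds shown alone.

Compound 3 `Nc1n[nH]c2cc(-c3ccc(=O)n(Cc4cccc(F)c4)c3)ccc12` gives 5 nM in an assay for inhibition of MAP kinase-interacting serine/threonine-protein kinase 2 (Homo sapiens), read by luminescence and ADP-Glo, with a stated time of 2 h; on this read-out higher numbers stand for weaker inhibition and lower numbers for stronger inhibition. Among the three numbers measured it stands second highest. Its nearest neighbour is compound 1 `Nc1n[nH]c2cc(-c3ccc(=O)n(Cc4ccccc4F)c3)ccc12`, which in this assay gives 4 nM, a number within the scatter of that for compound 3. The furthest is compound 2 `O=c1ccc(-c2ccc3cn[nH]c3c2)cn1Cc1ccccc1`, which in this assay gives 75 nM, a number beyond the scatter from compound 3. Compound 2 differs from compound 3 in more than one place, so its value shows only that the two lie well apart.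

Compound 4 `Nc1n[nH]c2cc(-c3ccc(=O)n(Cc4ccccc4)c3)ccc12` has not yet been measured. It differs from compound 3 by hydrogen in place of fluoro on an aromatic carbon. Going by the values given here, one measured step bears on this change: a 1.3-fold higher number from compound 1 to compound 3 (0.10 log units; within the scatter), which moved the fluoro from one position on the same ring to another. Because a 1.3-fold higher number from compound 1 to compound 3 (0.10 log units; within the scatter) stayed within the scatter, removing the fluoro altogether is expected to matter little, and the estimated step of no change at the digits printed from compound 3 to compound 4 (within the scatter) carries no direction beyond the scatter. Compound 4 is therefore expected to give 5 nM in this assay, with a range from 2.5 nM to 10 nM.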

Compound 4, half-maximal inhibitory concentration: 32 nM
For compound 4 the middle estimate is 6.4-fold (0.81 log units) below the measured one; measured number above the stated range.
By their numbers in this assay, from the lowest: compounds 1 and 3 (each within the scatter of the next); then compound 4; then compound 2.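

In this assay, the fluoro turns out to count after all: removing it gives a step beyond the scatter from either fluorinated compound (a 6.4-fold higher number from compound 3 to compound 4 (0.81 log units; beyond the scatter); an 8.0-fold higher number from compound 1 to compound 4 (0.90 log units; beyond the scatter)), even though moving it from the 2-fluorophenyl to the 3-fluorophenyl arrangement stayed within the scatter (a 1.3-fold higher number from compound 1 to compound 3 (0.10 log units; within the scatter)). So the two fluorinated compounds, which cannot be told apart in this assay, both stand apart from the plain benzyl compound, and a step that only relocates the fluoro says little about what its removal does. The amino group on the shared core is now also seen in a one-place comparison, on a benzyl compound without fluoro (a 2.3-fold lower number from compound 2 to compound 4 (0.37 log units; beyond the scatter)), but nothing given here accounts for either step.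

The compounds shown leave open whether another group in the same place, such as a chloro, a methoxy or a trifluoromethyl group, would go with numbers like those of the fluorinated compounds or like that of the plain benzyl compound. They also leave open how much the fluoro would count on a compound lacking the amino group, or with a methylamino group in its stead.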